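From chloro to 4-methylpiperazin-1-yl on a carbonyl carbon

The source may hold more compounds than are shown below. What is called first, only, known or untested is meant among the compounds shown, and "the series" means these compounds.

In a functional assay on HCT-116 cells (Homo sapiens) for inhibition, read by ELISA, with a stated time of 24 h (a higher number here means a weaker inhibitor of growth, a lower number a stronger inhibitor of growth), compound 1 `O=C(Cl)/C=C/c1ccccc1OC(=O)c1ccccc1` gives > 100000 nM as a limit of the assay and not a number. Compound 2 `CO/N=C/C=C/c1ccccc1OC(=O)c1ccccc1` gives > 100000 nM as a limit too. Compound 3 `O=C(/C=C/c1ccccc1O)NO` gives 16800 nM and is the only one of the three with a number. Compound 1 thus offers no number to start from, and the set shows the limit of > 100000 nM in this assay, at which 2 of the 3 values shown sit, as its main feature.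

Compound 4 `CN1CCN(C(=O)/C=C/c2ccccc2OC(=O)c2ccccc2)CC1` has not yet been measured. It keeps the core of compound 1 and carries this change: 4-methylpiperazin-1-yl in place of chloro on a carbonyl carbon with 4-methylpiperazin-1-yl in place of chloro on a carbonyl carbon. For the measured compounds named here, the one measured step that bears on it is a step that the two limits leave unreadable from compound 1 to compound 2 and this step, which also takes away the chloro, gives no size to carry over. No readable step is therefore expected in this assay and compound 4 is expected to remain weak, close to the limit or at it. In size, the expected change is an at least 1.1-fold lower number from compound 1 to compound 4 (0.04 log units; that floor lies within the scatter) and it rests on very little. Compound 4 is estimated at 90000 nM with an expected range from 30000 nM to 150000 nM and a good chance that the assay reports only a limit.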

Compound 4, concentration for 50% growth inhibition: > 100000 nM
Compound 4 was reported as a limit; the forecaster's own chance of this, stated with the estimate: 60%; middle value at least 1.1-fold (0.04 log units) away from the limit.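

In this assay compound 1 and compound 4 are both reported only as limits of the assay, so the step between them cannot be read. The compounds shown leave open how far 4-methylpiperazin-1-yl in place of chloro on a carbonyl carbon changes growth inhibition, because the readings stop at one value: the limit of > 100000 nM in this assay, at which 3 of the 4 values shown sit.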